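Swapping the aryl group on the ether oxygen of compound 3

A few compounds are considered here, and "the series" means these few. Any claim that something is new, unique, unknown or untested is made for them only; others in the source may bear on it.

Three measured compounds share one core and differ only in the aromatic group sitting on an oxygen on a saturated carbon. In an assay for inhibition of Thromboxane-A synthase (Homo sapiens), using microsomes (a higher number here means a weaker inhibitor, a lower number a stronger inhibitor), compound 1 `CC(C)(C)c1ccc(OC(C)(C)C2OCC(C/C=C\CCC(=O)O)C(c3cccnc3)O2)cc1` gives 280 nM. Compound 2 `Cc1ccc(OC(C)(C)C2OCC(C/C=C\CCC(=O)O)C(c3cccnc3)O2)cc1` gives 360 nM in this assay. Compound 3 `CC(C)(Oc1ccccc1F)C1OCC(C/C=C\CCC(=O)O)C(c2cccnc2)O1` gives 45 nM in this assay. The steps between them are a 1.3-fold higher number from compound 1 to compound 2 (0.11 log units; within the scatter), a 6.2-fold lower number from compound 1 to compound 3 (0.79 log units; beyond the scatter) and an 8.0-fold lower number from compound 2 to compound 3 (0.90 log units; beyond the scatter), so compound 3 stands at the lowest number of the three, separated from both others by steps beyond the scatter.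

Compound 4 `COc1ccc(OC(C)(C)C2OCC(C/C=C\CCC(=O)O)C(c3cccnc3)O2)c([N+](=O)[O-])c1` has not yet been measured. It differs from compound 3 at the same place: 4-methoxy-2-nitrophenyl in place of 2-fluorophenyl on an oxygen on a saturated carbon. The two measured steps that bear on this change are a 6.2-fold lower number from compound 1 to compound 3 (0.79 log units; beyond the scatter) and an 8.0-fold lower number from compound 2 to compound 3 (0.90 log units; beyond the scatter), both modest, both running toward a lower number when 2-fluorophenyl replaced 4-(tert-butyl)phenyl or 4-methylphenyl. For the measured compounds named here, no measured compound carries a nitro or a methoxy group, so the entering group itself gives no direct guidance. Since 2-fluorophenyl departs, a modest return toward a higher number is expected, a 2.7-fold higher number from compound 3 to compound 4 (0.43 log units; beyond the scatter). Compound 4 is therefore expected to give about 120 nM in this assay, within a range from 40 nM to 400 nM.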

Compound 4, half-maximal inhibitory concentration: 37 nM
Estimate against measurement, compound 4: 3.2-fold (0.51 log units) above; measured number outside the range, below it.
By their numbers in this assay, from the lowest: compounds 4 and 3 (each within the scatter of the next); then compounds 1 and 2 (each within the scatter of the next).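

The aryl group on this oxygen can grow without the number moving out of the low range: 4-methoxy-2-nitrophenyl has 11 heavy atoms and 3 hydrogen-bond acceptors against 7 and 0 for 2-fluorophenyl, yet this assay gives a 1.2-fold lower number from compound 3 to compound 4 (0.09 log units; within the scatter) for this swap. The low number of compound 3 is therefore not unique to 2-fluorophenyl, since the new group also stands apart from the two earlier aryl groups, with a 9.7-fold lower number from compound 2 to compound 4 (0.99 log units; beyond the scatter) against 4-methylphenyl and a 7.6-fold lower number from compound 1 to compound 4 (0.88 log units; beyond the scatter) against 4-(tert-butyl)phenyl. Compounds 1 and 2 had suggested that a group named at the 4 of the ring might go with the higher numbers, but compound 4 goes against that reading, as its 4-methoxy group comes with a number in the same low range as compound 3.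

Nothing shown here gives a reason why these two aryl groups sit so far from the other two. On these data alone, the nitro and methoxy groups enter together, so their separate contributions stay open, as does how an aryl ring carrying an amine or a carboxylic acid at this place would behave.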